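Moving the hydroxyl on the phenyl of compound 1

This account rests on a few compounds, and the source may have more. Where it says the series, first, only, none or still open, it means among the compounds named here.

The series is followed in an assay on cells for displacement of a labelled ligand from adenosine receptor A1 (Homo sapiens), read by scintillation counting and radioligand binding, with a stated time of 60 min; on this read-out lower numbers stand for stronger inhibition and higher numbers for weaker inhibition. Among the measured compounds shown here, compound 1 `Oc1cccc(-c2nc(N3CCCCC3)c3nc[nH]c3n2)c1` gives 10 nM there and stands lowest of the two numbers measured so far. Compound 2 `CN1CCN(c2nc(-c3cccc(O)c3)nc3[nH]cnc23)CC1`, in which 4-methylpiperazin-1-yl replaces piperidin-1-yl on an aromatic carbon, gives 158 nM; the step of a 16-fold higher number from compound 1 to compound 2 (1.20 log units; beyond the scatter) shows how much weight the amine on the shared core carries.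

Compound 3 `Oc1ccc(-c2nc(N3CCCCC3)c3nc[nH]c3n2)cc1` is not yet measured. It differs from compound 1 by 4-hydroxyphenyl in place of 3-hydroxyphenyl on an aromatic carbon. For the measured compounds named here, the only measured step, a 16-fold higher number from compound 1 to compound 2 (1.20 log units; beyond the scatter), concerns the amine and not the hydroxyphenyl, so nothing measured bears directly on this change. The shared core and the piperidin-1-yl group are kept, which argues against a step of the size seen between compound 1 and compound 2, but a shift of the hydroxyl on the phenyl leaves the direction open. For compound 3 the expected number is 30 nM in this assay, within a range of 8 nM to 120 nM. This corresponds to an estimated step of a 3.0-fold higher number from compound 1 to compound 3 (0.48 log units; beyond the scatter), which may or may not exceed the scatter.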

Compound 3, inhibition constant: 10 nM
Estimate against measurement, compound 3: 3.0-fold (0.48 log units) above; low and high end bracket the measured number.
By their numbers in this assay, from the lowest: compounds 1 and 3 (each within the scatter of the next); then compound 2.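

In this assay, moving the hydroxyl gives no change at the digits printed from compound 1 to compound 3 (within the scatter), so 4-hydroxyphenyl and 3-hydroxyphenyl cannot be told apart in this assay while the piperidin-1-yl group and the shared core are kept. Among the compounds shown here, the earlier compounds gave only a 16-fold higher number from compound 1 to compound 2 (1.20 log units; beyond the scatter), which concerns the amine, so this is the first reading at the hydroxyphenyl position, and the hydroxyl placement tested here leaves the number unmoved. No supporting data explain why the two placements read alike.

What the compounds shown leave open is whether the hydroxyl matters at all at this position, since neither a plain phenyl nor a methoxy group in place of the hydroxyl appears among them. Also open is whether the same match between the two placements would hold with 4-methylpiperazin-1-yl on the shared core, since 4-hydroxyphenyl is shown here only alongside piperidin-1-yl.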